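From 2,4-dihydroxyphenyl to 4-(dimethylamino)phenyl in a growth test

The source may hold more compounds than are shown below. What is called first, only, known or untested is meant among the compounds shown, and "the series" means these compounds.

Within the data shown here, in a functional assay on DU-145 cells (Homo sapiens) for inhibition, read by trypan blue exclusion, with a stated time of 96 h (on this read-out higher numbers stand for weaker inhibition of growth and lower numbers for stronger inhibition of growth), compound 1 (`O=C(/C(=C\c1ccc(O)cc1O)Sc1ccc(Br)cc1)c1ccc(Cl)cc1`) gives 50000 nM and sits at the top of the three numbers so far, level with compound 3 (`O=C(/C(=C\c1ccc(O)cc1O)SCc1ccc(Cl)cc1)c1ccc(Cl)cc1`) at 50000 nM in the same test. Compound 2 (`O=C(/C(=C\c1ccc(O)c([N+](=O)[O-])c1)SCc1ccc(Br)cc1)c1c(F)c(F)c(F)c(F)c1F`) gives the lowest number at 10000 nM but differs from compound 1 in more than one place.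

The next compound, compound 4 (`CN(C)c1ccc(/C=C(/Sc2ccc(Br)cc2)C(=O)c2ccc(Cl)cc2)cc1`), keeps the core of compound 1 and carries 4-(dimethylamino)phenyl in place of 2,4-dihydroxyphenyl on a double-bonded chain carbon bound to a double-bonded chain carbon.

Among the measured compounds shown here, only one measured step alters a single place, and it lies elsewhere: 4-chlorobenzyl in place of 4-bromophenyl on a sulfur gave no change at the digits printed from compound 1 to compound 3 (within the scatter) in this assay and so offers no direct guide here. For the measured compounds named here, no measured step touches the place that changes in compound 4, which leaves the expectation loose. Compound 2 at 10000 nM shows that lower numbers do occur in this small set, while compound 1 already stands at the top, so a modest move toward stronger inhibition is expected. The estimated change is a 2.5-fold lower number from compound 1 to compound 4 (0.40 log units; beyond the scatter) in that direction, with no change beyond the scatter still possible. For compound 4 the expected value is 20000 nM within an estimated range of 5000 nM to 60000 nM in this test.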

Compound 4, concentration for 50% growth inhibition: > 100000 nM
Compound 4: no number, only a limit; the forecaster's own chance of this, stated with the estimate: 15%; at least 5.0-fold (0.69 log units) between middle value and limit.
By their numbers in this assay, from the lowest: compound 2; then compounds 1 and 3 (each within the scatter of the next). At a limit, above all of these: compound 4.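

Among these compounds, this is the first step measured at this place, on a double-bonded chain carbon bound to a double-bonded chain carbon, where 2,4-dihydroxyphenyl, with 2 hydrogen-bond donors, gives way to 4-(dimethylamino)phenyl, with 0. In this assay, among the compounds shown here, the exchange gives an at least 2.0-fold higher number from compound 1 to compound 4 (0.30 log units; that floor lies within the scatter), so the only thing the step establishes is that this group does not bring the number down from where the 2,4-dihydroxyphenyl compound stands, and the size of any rise remains unsettled. Compound 4 has no number, only a limit: the limit of > 100000 nM in this assay, at which 1 of the 4 values shown sits.

The compounds shown leave open which side of the exchange carries the step, the two hydroxyl groups that leave or the dimethylamino group that enters, and a plain phenyl or a 4-hydroxyphenyl at this place would begin to separate the two. Going by these compounds, it also remains open whether the same exchange would read alike on compound 3, which carries 4-chlorobenzyl on the sulfur, or whether a primary amine in place of the dimethylamino group would give a number at all.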